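Quinazoline series: hydroxy to sulfanyl at the two-nitrogen ring carbon

This account rests on a few compounds, and the source may have more. Where it says the series, first, only, none or still open, it means among the compounds named here.

Compound 3 `Nc1nc(O)nc2ccc(Sc3ccc4ccccc4c3)cc12` gives 5.77 in an assay for inhibition of Dihydrofolate reductase (Homo sapiens) (on this read-out lower numbers stand for lower potency and higher numbers for higher potency (the scale is a negative logarithm)), the highest of the three numbers measured; its nearest neighbour is compound 1 `Sc1nc(S)c2cc(Sc3ccc4ccccc4c3)ccc2n1` at 5.05, and the furthest is compound 2 `Nc1ncnc2ccc(Sc3ccc4ccccc4c3)cc12` at 4.68, both beyond the scatter below it. Within the data shown here, the one recorded step, a number 1.09 log units higher from compound 2 to compound 3 (beyond the scatter), shows what adding the hydroxy does at the carbon between two ring nitrogen atoms.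

Compound 4 `Nc1nc(S)nc2ccc(Sc3ccc4ccccc4c3)cc12` is compound 3 with the change (sulfanyl in place of hydroxy on an aromatic carbon). Among the measured compounds shown here, no measured pair exchanges hydroxy for sulfanyl at this place, so that step has no direct precedent. Compound 1, which carries sulfanyl at this carbon but differs from compound 3 in a second place as well, stands lower, which leaves open whether the sulfanyl itself costs potency. A moderate downward step is therefore expected for compound 4, a number 0.32 log units lower from compound 3 to compound 4 (beyond the scatter), with the range kept wide. Compound 4 is estimated at 5.45, between 4.85 and 6.05.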

Compound 4, logarithm of the reciprocal of the active concentration, log(1/C): 5.52
Beside the measured number, compound 4's estimate is 0.07 log units below it; low and high end bracket the measured number.
By their numbers in this assay, from the lowest: compound 2; then compound 1; then compounds 4 and 3 (each within the scatter of the next).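

At the carbon between two ring nitrogen atoms, sulfanyl in place of hydroxy gives a number 0.25 log units lower from compound 3 to compound 4 (within the scatter) in this assay and so does not separate the two groups. Sulfanyl in place of hydrogen at the same carbon gives a number 0.84 log units higher from compound 2 to compound 4 (beyond the scatter) and shows that the gain over hydrogen seen with hydroxy also appears with a second group. With sulfanyl held at this carbon, amino in place of sulfanyl at the other differing aromatic carbon gives a number 0.47 log units higher from compound 1 to compound 4 (beyond the scatter) and indicates that sulfanyl at this carbon does not account for the low standing of compound 1.

Going by these compounds, whether a methoxy group or a carboxylic acid at this carbon would keep the gain over hydrogen stays open. No measurement at hand bears on the reason for that gain.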